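Replacing the benzamido group of compound 1

The source may report more compounds than this note shows. Statements on the series, on what has been measured and on what is new or still open speak of the compounds shown alone.

Values so far in a functional assay on JeKo-1 cells (Homo sapiens) for antiproliferative activity (on this read-out higher numbers stand for weaker inhibition and lower numbers for stronger inhibition), by compound:

compound 1 `Nc1ncnc2c1c(-c1ccc(NC(=O)c3ccccc3)cc1)cn2[C@H]1CCN(C[C@@H]2CO2)C1` gives 5390 nM
compound 2 `Nc1ncnc2c1c(-c1ccc(Oc3ccccc3)cc1)cn2C[C@H]1CCCN1C[C@@H](O)CO` gives 9540 nM
compound 3 `Nc1ncnc2c1c(-c1ccc(C(=O)Nc3ccc(Oc4ccccc4)cc3)cc1)cn2[C@H]1CCN(C[C@@H]2CO2)C1` gives 2070 nM

Compound 1 gives 5390 nM and so stands within the usual scatter of compound 2 (9540 nM). Compound 3 (2070 nM) gives a lower number than compound 1, and that gap lies beyond the scatter.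

The next compound is compound 4 (`CC(C)(C)c1ccc(COc2ccc(-c3cn([C@H]4CCN(C[C@@H]5CO5)C4)c4ncnc(N)c34)cc2)cc1`), which differs from compound 1 in one place: (4-(tert-butyl)benzyl)oxy in place of benzamido on an aromatic carbon.

Among the measured compounds shown here, no two measured compounds differ in just one place, so no direct step is available as a guide. The nearest hint is compound 3, which also carries a larger group than benzamido at that spot and gives 2070 nM in this assay as its reading. For the measured compounds named here, this is thin support, since it rests on a single compound whose group differs from the one in compound 4.

The expected change is small and toward a lower number, not clearly beyond the scatter, as the estimated 1.8-fold lower number from compound 1 to compound 4 (0.25 log units; within the scatter) shows. For compound 4 the estimate is 3000 nM with an expected range from 1000 nM to 9000 nM for the measurement.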

Compound 4, half-maximal inhibitory concentration: 5970 nM
Compound 4: the middle estimate sits 2.0-fold (0.30 log units) below what was measured; low and high end bracket the measured number.
By their numbers in this assay, from the lowest: compound 3; then compounds 1, 4 and 2 (each within the scatter of the next).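

Among the compounds shown here, this is the first direct reading at this position in this assay: putting (4-(tert-butyl)benzyl)oxy in place of benzamido gives a 1.1-fold higher number from compound 1 to compound 4 (0.04 log units; within the scatter), so the two compounds cannot be told apart here. The swap takes away the hydrogen-bond donor of benzamido, along with its nitrogen and its double bond, and the group grows from 9 to 12 heavy atoms, yet in this one pair these differences come with no readable change in the number. Nothing measured here explains why the number stays put, so this pair offers no cause for the result.

Still open, from the compounds shown here alone, is whether a different kind of group on this aromatic carbon, such as a simple amine or a carboxylic acid, would move the number beyond the scatter. One pair also cannot separate the parts of the new group, so a plain benzyloxy group without the tert-butyl end, or a longer chain between the oxygen and the ring, would be needed to show whether either part matters on its own.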